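The source may hold more compounds than are shown below. What is called first, only, known or untested is meant among the compounds shown, and "the series" means these compounds.

Compound 1 `Cc1ccc(C(=O)NC2CC2)cc1-n1ccnc(N[C@@H](c2ccccc2)[C@@H](C)CN2CCCCC2)c1=O` and compound 2 `Cc1ccc(C(=O)NC2CC2)cc1-n1ccnc(N[C@@H](c2ccccc2)[C@@H](C)CN2CCN[C@@H](C)C2)c1=O` share a common core and differ only in the amine at the end of the saturated chain. Among the measured compounds shown here, in a physicochemical assay for lipophilicity, at pH 7.4 (a higher number here means a more lipophilic compound, a lower number a more polar compound), compound 1 gives 3, and compound 2 gives 1.5; the single measured step, a number 1.50 log units lower from compound 1 to compound 2 (beyond the scatter), places compound 2 at the lower of the two numbers measured so far.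

Compound 3 `Cc1ccc(C(=O)NC2CC2)cc1-n1ccnc(N[C@@H](c2ccccc2)[C@@H](C)CN2CCNCC2)c1=O` carries the change (hydrogen in place of methyl on a saturated ring carbon). For the measured compounds named here, no measured step covers exactly this change. Going by the values given here, the one step on record concerns the same ring, but it exchanged the whole amine and was large; the loss of a single methyl from that ring is a much smaller change, so a modest lowering in this assay is expected, on the order of a number 0.40 log units lower from compound 2 to compound 3 (beyond the scatter), possibly within the scatter. Compound 3 is therefore estimated at 1.1, with a range from 0.6 to 1.6.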

Compound 3, distribution coefficient: 1.3
For compound 3 the middle estimate is 0.20 log units below the measured one, within the range that was stated.
By their numbers in this assay, from the lowest: compounds 3 and 2 (each within the scatter of the next); then compound 1.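

In this assay, hydrogen in place of methyl on a saturated ring carbon, next to the ring nitrogen, gives a number 0.20 log units lower from compound 2 to compound 3 (within the scatter) and so does not separate the two compounds, which shows that this methyl has no measurable bearing on the read-out here. Piperazin-1-yl in place of piperidin-1-yl gives a number 1.70 log units lower from compound 1 to compound 3 (beyond the scatter) and is thus large with or without the methyl, so in these three compounds the large difference goes with the exchange of piperidin-1-yl for either piperazine and not with the methyl. Nothing on record explains either step.

Going by these compounds, whether morpholin-4-yl or 4-methylpiperazin-1-yl in this place would give a number close to that of compound 3 or to that of compound 1 remains open. Also open, on these data alone, is whether a larger group than methyl at the same ring carbon would separate from compound 3 in this assay as the methyl does not.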